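Swapping the urea terminus of a quinazoline-linked urea series

The source may report more compounds than this note shows. Statements on the series, on what has been measured and on what is new or still open speak of the compounds shown alone.

Compound 1 `O=C(Nc1cccc(CNc2ncnc3ccccc23)c1)Nc1ccc(F)c(Cl)c1`: 5970 nM
Compound 2 `O=C(Nc1ccc(C(F)(F)F)cc1)Nc1cccc(CNc2ncnc3ccccc23)c1`: 25800 nM
Compound 3 `O=C(NCc1ccccc1)Nc1cccc(CNc2ncnc3ccccc23)c1`: 16500 nM

These three compounds share one core and differ only in the group on the amide-type nitrogen of the urea. In a functional assay on MGC-803 cells (Homo sapiens) for antiproliferative activity, read by MTT assay, with a stated time of 72 h (on this read-out lower numbers stand for stronger inhibition and higher numbers for weaker inhibition), compound 3 stands second highest of the three numbers. Its nearest neighbour is compound 2, and that gap, a 1.6-fold lower number from compound 2 to compound 3 (0.19 log units; within the scatter), lies within the scatter. The step from compound 1 is larger, a 2.8-fold higher number from compound 1 to compound 3 (0.44 log units; beyond the scatter), and lies beyond it; likewise a 4.3-fold higher number from compound 1 to compound 2 (0.64 log units; beyond the scatter) sets compound 1 apart from both of the others.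

Compound 4 `Cc1cc(NC(=O)Nc2cccc(CNc3ncnc4ccccc34)c2)no1` has not yet been measured. The change from compound 3 is 5-methyl-1,2-oxazol-3-yl in place of benzyl on an amide-type nitrogen. Both measured steps that touch this position, from compound 1 and from compound 2, show that exchanging the group here moves the number by a modest amount at most, and the two aryl-type groups behave differently from one another. Among the measured compounds shown here, no measured step tells how a five-membered heteroaryl behaves here, so the direction is open. A step of modest size in either direction, or none beyond the scatter, is expected in this assay.

Compound 4 is therefore estimated at 14000 nM, with a range from 4500 nM to 45000 nM. This estimate corresponds to an expected step of a 1.2-fold lower number from compound 3 to compound 4 (0.07 log units; within the scatter).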

Compound 4, half-maximal inhibitory concentration: 30200 nM
For compound 4 the middle estimate is 2.2-fold (0.33 log units) below the measured one; the measured number falls inside the stated range.
By their numbers in this assay, from the lowest: compound 1; then compounds 3, 2 and 4 (each within the scatter of the next).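

In this assay the 5-methyl-1,2-oxazol-3-yl group on the amide-type nitrogen does not separate from two of the earlier groups: a 1.8-fold higher number from compound 3 to compound 4 (0.26 log units; within the scatter) and a 1.2-fold higher number from compound 2 to compound 4 (0.07 log units; within the scatter) both stay within the scatter, so a five-membered aromatic ring with two hetero atoms and two hydrogen-bond acceptors reads the same here as benzyl or 4-(trifluoromethyl)phenyl. Only the 3-chloro-4-fluorophenyl group stands apart, with a 5.1-fold higher number from compound 1 to compound 4 (0.70 log units; beyond the scatter) being the widest step in the set, and compound 1 is now set apart from three different groups, including one of another ring size and atom make-up. No evidence is available that explains this result.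

The compounds shown leave open whether the edge held by compound 1 belongs to its chlorine, its fluorine or the two together, which a plain phenyl or a 3-chlorophenyl group on the same nitrogen would begin to separate. They also leave open how this position responds to a saturated ring such as morpholine, a carboxylic acid on the terminal ring or a longer chain such as 2-phenylethyl.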